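Fluorine on the phenyl ring of compound 1

The compounds below may be only part of what the source reports. "The series", "measured", "known", "first", "only" and "open" are said of these compounds alone.

Measured so far, in a functional assay on MCF7 cells (Homo sapiens) for cytotoxicity, read by MTT assay, with a stated time of 4 days; a lower number here means a stronger inhibitor, a higher number a weaker inhibitor:
- compound 1, `Cc1c(O)ccc2c1[C@H](Cn1cc(-c3ccccc3)nn1)[C@@]13CC(=O)[C@@](C)(CC[C@@H]21)C3`, gives only a limit, > 20000 nM.
- compound 2, `Cc1ccc(S(=O)(=O)Oc2ccc3c(c2C)[C@H](Cn2cc(-c4ccccc4)nn2)[C@@]24CC(=O)[C@@](C)(CC[C@@H]32)C4)cc1`, also gives only a limit, > 20000 nM.

Compound 1 therefore has no number of its own in this assay, only a limit. Going by the values given here, the one measured step, a step that the two limits leave unreadable from compound 1 to compound 2, cannot be read in size or direction, since both of its values sit at the limit of > 20000 nM in this assay, at which 2 of the 2 values shown sit.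

Compound 3, `Cc1c(O)ccc2c1[C@H](Cn1cc(-c3ccc(F)cc3)nn1)[C@@]13CC(=O)[C@@](C)(CC[C@@H]21)C3`, is not yet measured. It differs from compound 1 in one place: fluoro in place of hydrogen on an aromatic carbon. Among the compounds with values here, no measured step touches this kind of change; the only step in hand, from a free hydroxyl to a (4-methylphenyl)sulfonyl on that oxygen, is unreadable, so it gives no guide to the size or direction of the new step.

With the parent at a limit and no readable step to lean on, compound 3 is expected to stay at or near the same limit in this assay. The expected value for compound 3 is 30000 nM, within a range of 8000 nM to 120000 nM. This estimate means a step that the limit leaves unreadable from compound 1 to compound 3, expected to lie within the scatter.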

Compound 3, half-maximal inhibitory concentration: > 20000 nM
Compound 3 was reported as a limit (the forecaster's own chance of this, stated with the estimate: 80%); the middle value does not contradict the limit.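

Compound 3, like compound 1, gives only a limit in this assay, so the change from phenyl to 4-fluorophenyl cannot be read in size or direction: the limit of > 20000 nM in this assay, at which 3 of the 3 values shown sit.

The compounds shown leave open what structure, if any, would give an actual number in this assay, and so whether fluoro in this place makes any difference.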